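The source may report more compounds than this note shows. Statements on the series, on what has been measured and on what is new or still open speak of the compounds shown alone.

Compound 1 `Clc1ccc(-c2nnc(-c3cn4ccccc4n3)o2)cc1` was tested in a functional assay on A549 cells (Homo sapiens) for antiproliferative activity, read by MTT assay, with a stated time of 48 h (on this read-out lower numbers stand for stronger inhibition and higher numbers for weaker inhibition), where compound 1 gives 32400 nM. Compound 2 `Brc1ccc(-c2nnc(-c3cn4ccccc4n3)o2)cc1` differs from it by bromo in place of chloro on an aromatic carbon. In this assay compound 2 reaches only a limit, > 50000 nM. The step is an at least 1.5-fold higher number from compound 1 to compound 2 (0.18 log units; that floor lies within the scatter), and the limit reached is the limit of > 50000 nM in this assay, at which 1 of the 3 values shown sits. Compound 3 `Cc1cc(Br)c2nc(-c3nnc(-c4ccc(Cl)cc4)o3)cn2c1` is built on a different core; the difference between the two cores is not broken down here. In this assay compound 3 gives 43500 nM. For the measured compounds named here, compound 4 `Cc1cc(Br)c2nc(-c3nnc(-c4ccc(Br)cc4)o3)cn2c1` has not yet been measured; it differs from compound 3 by bromo in place of chloro on an aromatic carbon, the same change, at the same place, as the one from compound 1 to compound 2. For compound 4 the expected step is a 1.5-fold higher number from compound 3 to compound 4 (0.17 log units; within the scatter), which is estimated to be about as large as or somewhat larger than the measured step of an at least 1.5-fold higher number from compound 1 to compound 2 (0.18 log units; that floor lies within the scatter), because compound 2 already reached (the limit of > 50000 nM in this assay, at which 1 of the 3 values shown sits). Compound 4 is therefore estimated at 65000 nM, within a range from 35000 nM to 130000 nM, and it is expected that the assay may again report only a limit.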

Compound 4, half-maximal inhibitory concentration: 23400 nM
Compound 4: the middle estimate sits 2.8-fold (0.44 log units) above what was measured; the whole stated range lies above it.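

Read alone, the new step in this assay is small, a 1.9-fold lower number from compound 3 to compound 4 (0.27 log units; within the scatter), yet the same change from 4-chlorophenyl to 4-bromophenyl does not run the same way on the two cores: the same change on two cores in this assay, an at least 1.5-fold higher number (0.18 log units; that floor lies within the scatter) from compound 1 to compound 2 and a 1.9-fold lower number (0.27 log units; within the scatter) from compound 3 to compound 4, at least 2.8-fold (0.45 log units) apart, beyond the scatter of two such steps

In this series, then, the result of this change on one core cannot simply be carried over to the other. It does not show why the two cores differ or what would happen on any further core, and the earlier step rests on compound 2, whose > 50000 nM is a limit of the assay and not a number.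

The compounds shown carry only chloro or bromo at this place, so it stays open how a group such as an amine, a carboxylic acid or a longer chain would behave there on either core. Also open, as far as these compounds go, is which part of the core of compound 3 sets its step apart from the one on the core of compound 1.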